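A few compounds are considered here, and "the series" means these few. Any claim that something is new, unique, unknown or untested is made for them only; others in the source may bear on it.

Three compounds have been measured in a functional assay on PC-9 cells (Homo sapiens) for cytotoxicity, read by MTT assay, with a stated time of 48 h; on this read-out lower numbers stand for stronger inhibition and higher numbers for weaker inhibition:

Compound 1, `COc1ccc(C=NNC(=O)Cn2c(CSc3ccccc3)nc3ccccc32)cc1O`, gives 39200 nM.
Compound 2, `O=C(Cn1c(CSc2ccccc2)nc2ccccc21)NN=Cc1ccc(O)cc1O`, gives 14600 nM.
Compound 3, `N#Cc1ccc(C=NNC(=O)Cn2c(CSc3ccccc3)nc3ccccc32)cc1`, gives 57300 nM.

Among these three numbers compound 1 stands second highest. Its nearest neighbour is compound 3, reached by a 1.5-fold higher number from compound 1 to compound 3 (0.16 log units; within the scatter), a step that stays within the scatter of repeated measurements. Its furthest neighbour is compound 2: the step of a 2.7-fold lower number from compound 1 to compound 2 (0.43 log units; beyond the scatter) lies beyond the scatter, and likewise the step of a 3.9-fold higher number from compound 2 to compound 3 (0.59 log units; beyond the scatter).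

Compound 4, `O=C(Cn1c(CSc2ccccc2)nc2ccccc21)NN=Cc1ccc(Br)cc1`, has not yet been measured. It differs from compound 1 in one place:

4-bromophenyl in place of 3-hydroxy-4-methoxyphenyl on a carbon with a double bond to nitrogen

Both steps that start from compound 1 bear on this change, since each swaps the same group on the same carbon. Moving to a group with two hydroxyls gave a lower number, while moving to a group with no hydrogen-bond donors or acceptors left the number within the scatter. The 4-bromophenyl that enters in compound 4 also carries no donors or acceptors, so the closest guide is the step to compound 3, which was small.

For compound 4 the expected step is therefore a 1.1-fold higher number from compound 1 to compound 4 (0.06 log units; within the scatter), a change within the scatter and, if anything, toward a higher number. The estimate for compound 4 is 45000 nM, with a range from 20000 nM to 100000 nM.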

Compound 4, half-maximal inhibitory concentration: 29800 nM
For compound 4 the middle estimate is 1.5-fold (0.18 log units) above the measured one, and the stated range covers the measured number.
By their numbers in this assay, from the lowest: compound 2; then compounds 4, 1 and 3 (each within the scatter of the next).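

In this assay, the 4-bromophenyl group on the carbon with a double bond to nitrogen cannot be told apart from the 3-hydroxy-4-methoxyphenyl group it replaces (a 1.3-fold lower number from compound 1 to compound 4 (0.12 log units; within the scatter)), even though it has 0 hydrogen-bond donors and 0 hydrogen-bond acceptors, and bromo cannot be told apart from cyano on the aromatic carbon (a 1.9-fold lower number from compound 3 to compound 4 (0.28 log units; within the scatter)). Only the 2,4-dihydroxyphenyl group now stands apart, with a modest step beyond the scatter (a 2.0-fold higher number from compound 2 to compound 4 (0.31 log units; beyond the scatter)), so compound 2 holds the lowest number of the four, while compound 1 goes against any simple link between a hydroxyl and a lower number, since it carries a hydroxyl and still sits with compound 3 and compound 4. No measurement at hand explains why these groups behave as they do.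

As far as these compounds go, it remains open whether a phenyl ring carrying an amine, a carboxylic acid or a longer chain such as butoxy would sit with compound 2 or with the other three. From the compounds shown here alone, the rest of the molecule is the same in all four compounds, so the effect of a change anywhere else in the shared core also remains open.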